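Swapping the Aryl Group: From Hydroxyphenyl to Dichlorophenyl

The source may hold more compounds than are shown below. What is called first, only, known or untested is meant among the compounds shown, and "the series" means these compounds.

Measured compounds:
- Compound 1 `COc1cc(N2C(N)=C(C#N)C(c3ccc([N+](=O)[O-])cc3)C3=C2CC(C)(C)CC3=O)cc(OC)c1OC`: 50%
- Compound 2 `COc1cc(N2C(N)=C(C#N)C(c3ccccc3O)C3=C2CC(C)(C)CC3=O)cc(OC)c1OC`: 0%

Both compounds share one core and differ only in the aryl group on a saturated ring carbon. In a functional assay on Ehrlich cells (Mus musculus) for cytotoxicity, tested at 25 ug/mL (on this read-out higher numbers stand for a stronger effect at the one concentration tested and lower numbers for a weaker effect), compound 1 gives 50%, while compound 2 gives 0%, the lowest of the two numbers. Going by the values given here, the single measured step, a number 50 percentage points lower from compound 1 to compound 2 (beyond the scatter), shows that exchanging this aryl group can move the read-out a long way.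

Compound 3 `COc1cc(N2C(N)=C(C#N)C(c3ccc(Cl)cc3Cl)C3=C2CC(C)(C)CC3=O)cc(OC)c1OC` is the next variation. The change from compound 2 is 2,4-dichlorophenyl in place of 2-hydroxyphenyl on a saturated ring carbon. Among the compounds with values here, only one measured step bears on it, the large drop of a number 50 percentage points lower from compound 1 to compound 2 (beyond the scatter), and that step concerns a different pair of aryl groups, so it sets no direct precedent for a 2,4-dichlorophenyl. Compound 3, like compound 1, carries no hydrogen-bond donor on its aryl ring, which is the only clue the data offer. A rise in this assay is therefore expected, of about a number 30 percentage points higher from compound 2 to compound 3 (beyond the scatter). For compound 3 the estimate in this assay is 30%, with a likely range from 0% to 65%.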

Compound 3, a percentage reported as activity, at one concentration (the size of the read-out at that concentration, not a potency): 55%
For compound 3 the middle estimate is 25 percentage points below the measured one; measured number inside the range.
By their numbers in this assay, from the lowest: compound 2; then compounds 1 and 3 (each within the scatter of the next).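

In this assay, the step of a number 55 percentage points higher from compound 2 to compound 3 (beyond the scatter) shows that the loss seen with 2-hydroxyphenyl is not a general feature of the shared core, since another aryl group on the same saturated ring carbon restores a clear effect. The step of a number 5 percentage points higher from compound 1 to compound 3 (within the scatter) shows that 4-nitrophenyl and 2,4-dichlorophenyl cannot be told apart here, so this position accepts at least two differently substituted aryl groups with no measurable difference between them. Of the three aryl groups, only 2-hydroxyphenyl carries a hydrogen-bond donor, and compound 2 alone sits apart from the other two, but with so few compounds this is an observation about these three and not a rule.

No supporting data are available to explain these differences. The compounds shown leave open whether the hydroxyl group itself or its place on the aryl ring goes with the low number, a question that unsubstituted phenyl, 4-hydroxyphenyl and 2-methoxyphenyl at this carbon could help to separate.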